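The compounds below may be only part of what the source reports. "The series", "measured", "known", "first", "only" and "open" are said of these compounds alone.

Compound 3 `Cc1cc(N2CCN(C)CC2)nc2ccc(NC(=O)c3ccc(Cl)c(Cl)c3)cc12` sits second highest of the three numbers in hand: in a functional assay on MCF7 cells (Homo sapiens) for antiproliferative activity, read by MTT assay, with a stated time of 72 h (on this read-out lower numbers stand for stronger inhibition and higher numbers for weaker inhibition), compound 3 gives 3000 nM. Its nearest neighbour is compound 1 `Cc1cc(NCCN2CCN(C)CC2)nc2ccc(NC(=O)c3ccc(Cl)c(Cl)c3)cc12`, which in this assay gives 1700 nM, the two separated only by a 1.8-fold higher number from compound 1 to compound 3 (0.25 log units; within the scatter). The furthest is compound 2 `Cc1cc(N(C)C)nc2ccc(NC(=O)c3ccc(Cl)c(Cl)c3)cc12`, which in this assay gives 33300 nM; the gap is an 11-fold lower number from compound 2 to compound 3 (1.05 log units; beyond the scatter).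

Compound 4 `CCNc1cc(C)c2cc(NC(=O)c3ccc(Cl)c(Cl)c3)ccc2n1` is not yet measured. It differs from compound 3 by ethylamino in place of 4-methylpiperazin-1-yl on an aromatic carbon.

Going by the values given here, two measured steps bear on this. The change an 11-fold lower number from compound 2 to compound 3 (1.05 log units; beyond the scatter) shows what arrives when the 4-methylpiperazin-1-yl replaces dimethylamino, and a 20-fold higher number from compound 1 to compound 2 (1.29 log units; beyond the scatter) shows the same loss in the other direction, from the (2-(4-methylpiperazin-1-yl)ethyl)amino compound. Ethylamino, like dimethylamino, carries no ring, so the step to compound 4 is expected to run the way of those two, beyond the scatter and toward the number of compound 2.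

For compound 4 the estimate in this assay is therefore 20000 nM, within 6000 nM to 60000 nM, a step of a 6.7-fold higher number from compound 3 to compound 4 (0.82 log units; beyond the scatter) expected from compound 3.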

Compound 4, half-maximal inhibitory concentration: 48600 nM
Beside the measured number, compound 4's estimate is 2.4-fold (0.39 log units) below it; measured number inside the range.
By their numbers in this assay, from the lowest: compounds 1 and 3 (each within the scatter of the next); then compounds 2 and 4 (each within the scatter of the next).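

In this assay, the step of a 16-fold higher number from compound 3 to compound 4 (1.21 log units; beyond the scatter) shows that a small open-chain ethylamino at this position, next to the ring nitrogen, does not keep the level seen with 4-methylpiperazin-1-yl. The step of a 29-fold higher number from compound 1 to compound 4 (1.46 log units; beyond the scatter) adds that the chain of compound 1 does not hold that level on its own once its terminal 4-methylpiperazin-1-yl is gone. The step of a 1.5-fold higher number from compound 2 to compound 4 (0.16 log units; within the scatter) shows no separation between ethylamino and dimethylamino, so the amine hydrogen that ethylamino carries makes no readable difference in this pair.

Morpholin-4-yl and piperidin-1-yl at this position would test whether the ring alone or its second nitrogen tracks with the lower numbers, and a two-carbon chain ending in dimethylamino would test the same for the terminal ring of compound 1. Nothing available here gives a measured reason for these differences.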